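Working notes: compound 4 against compound 3

The source may hold more compounds than are shown below. What is called first, only, known or untested is meant among the compounds shown, and "the series" means these compounds.

Values in a functional assay on ECa-109 cells for antiproliferative activity against ECa-109 cell line (Homo sapiens), read by MTT assay, with a stated time of 72 h (on this read-out higher numbers stand for weaker inhibition and lower numbers for stronger inhibition), so far
compound 1 `C/C(=N\NC(=O)c1cccc(S(=O)(=O)N2CCOCC2)c1)c1ccc(F)cc1` gives > 100000 nM as a limit
compound 2 `O=C(N/N=C/c1ccco1)c1cccc(S(=O)(=O)N2CCOCC2)c1` gives > 100000 nM as a limit
compound 3 `CCOc1cccc(/C=N/NC(=O)c2cccc(S(=O)(=O)N3CCOCC3)c2)c1O` gives 16500 nM as a number

Within the data shown here, compound 3 at 16500 nM holds the only number. Compound 1 and compound 2 stand at the limit of > 100000 nM in this assay, at which 2 of the 3 values shown sit, without a number. Compound 4 `O=C(N/N=C/c1cc(Br)cc(Br)c1O)c1cccc(S(=O)(=O)N2CCOCC2)c1` has no value yet. It carries 3,5-dibromo-2-hydroxyphenyl in place of 3-ethoxy-2-hydroxyphenyl on a carbon with a double bond to nitrogen, and the counted difference is 3,5-dibromo-2-hydroxyphenyl in place of 3-ethoxy-2-hydroxyphenyl on a carbon with a double bond to nitrogen with the rest of the structure unchanged.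

Among the measured compounds shown here, one measured step bears on this place, namely an at least 6.0-fold lower number from compound 2 to compound 3 (0.78 log units; beyond the scatter) with furan-2-yl giving way to 3-ethoxy-2-hydroxyphenyl. The starting point of that step is a limit. For the measured compounds named here, it offers only indirect guidance, as no measured step exchanges one substituted hydroxyphenyl group for another. Going by the values given here, compound 4 keeps a hydroxyphenyl group, so the expectation stays close to compound 3 at 16500 nM with a slight lean towards a lower number in this assay and no step of clear size. The expected change is a 1.4-fold lower number from compound 3 to compound 4 (0.14 log units; within the scatter) and remains within the usual scatter. For compound 4 the estimated value is 12000 nM with 3000 nM to 50000 nM as the expected range.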

Compound 4, half-maximal inhibitory concentration: 10300 nM
The estimate for compound 4 lay 1.2-fold (0.07 log units) above the measured number; the measured number falls inside the stated range.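

In this assay, 3,5-dibromo-2-hydroxyphenyl in place of 3-ethoxy-2-hydroxyphenyl on a carbon with a double bond to nitrogen gives a 1.6-fold lower number from compound 3 to compound 4 (0.20 log units; within the scatter), so these two substituted hydroxyphenyl groups cannot be told apart on this read-out. Among these compounds, with furan-2-yl giving way to 3,5-dibromo-2-hydroxyphenyl, the series shows an at least 9.7-fold lower number from compound 2 to compound 4 (0.98 log units; beyond the scatter), so compound 3 no longer stands alone as the only compound with a number, and a second hydroxyphenyl group now also gives one. That step is a bound only, as the value for compound 2 is a limit and not a number: the limit of > 100000 nM in this assay, at which 2 of the 4 values shown sit.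

As far as these compounds go, it remains open how a plain phenyl or a pyridine ring at this place would compare with the two hydroxyphenyl groups, and whether an amine or a carboxylic acid on the ring would carry the value beyond the scatter from compound 3. Also open, from the compounds shown here alone, is whether any other substituent pattern on the hydroxyphenyl group separates from compound 3 and compound 4, which so far lie within the scatter of each other.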